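A few compounds are considered here, and "the series" means these few. Any claim that something is new, unique, unknown or untested is made for them only; others in the source may bear on it.

In a functional assay on U2OS cells (Homo sapiens) for antiproliferative activity, read by MTT assay, with a stated time of 72 h (on this read-out higher numbers stand for weaker inhibition and lower numbers for stronger inhibition), compound 1 `O=C(CSc1nc2ccccc2[nH]1)Nc1ccc2nc(NC(=O)c3ccc(C(F)(F)F)cc3)sc2c1` gives 7110 nM and compound 2 `O=C(CSc1ncccn1)Nc1ccc2nc(NC(=O)c3ccc(C(F)(F)F)cc3)sc2c1` gives 28100 nM, so compound 2 holds the higher of the two numbers. Compound 3 `Cn1c(CNC(=O)c2cccs2)nnc1SCC(=O)Nc1ccc(Cl)cc1` is reported only as a limit, > 100000 nM.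

Compound 4 `O=C(CSc1ccc2ccccc2c1)Nc1ccc2nc(NC(=O)c3ccc(C(F)(F)F)cc3)sc2c1` has naphthalen-2-yl in place of pyrimidin-2-yl on a sulfur. Within the data shown here, the rest of compound 4 matches compound 2, and no measured step makes this exact exchange. One measured step changes the same place: a 4.0-fold higher number from compound 1 to compound 2 (0.60 log units; beyond the scatter), with pyrimidin-2-yl in place of 1H-benzimidazol-2-yl on a sulfur. That modest step leaves compound 1, with its 1H-benzimidazol-2-yl, as the member of the pair with the lower number. On this single pair, a modest step toward a lower number is expected when naphthalen-2-yl enters, although compound 4 carries a different group from compound 1. The expected change is a 3.1-fold lower number from compound 2 to compound 4 (0.49 log units; beyond the scatter). For compound 4 the estimated value is 9000 nM, with an expected range from 3000 nM to 28000 nM.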

Compound 4, half-maximal inhibitory concentration: 3940 nM
For compound 4 the middle estimate is 2.3-fold (0.36 log units) above the measured one; the measured number falls inside the stated range.
By their numbers in this assay, from the lowest: compounds 4 and 1 (each within the scatter of the next); then compound 2. At a limit, above all of these: compound 3.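

Naphthalen-2-yl in place of pyrimidin-2-yl gives a 7.1-fold lower number from compound 2 to compound 4 (0.85 log units; beyond the scatter), so pyrimidin-2-yl now has the higher number against two different groups on this sulfur. Naphthalen-2-yl, made of carbon only and with no hydrogen-bond acceptors, also stands level with 1H-benzimidazol-2-yl, with a 1.8-fold lower number from compound 1 to compound 4 (0.26 log units; within the scatter), so a number in this range does not depend on nitrogen in the group on the sulfur. Nothing available gives a cause for these steps.

As far as these compounds go, it remains open whether a plain phenyl group would stay with these two groups or with pyrimidin-2-yl. Also open, from the compounds shown here alone, is how an amine or a carboxylic acid on the naphthalen-2-yl group, or an oxygen in place of the sulfur, would change the number.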